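Benzoyl amide in a benzyloxy-chlorobenzyl pyrazole series

This account rests on a few compounds, and the source may have more. Where it says the series, first, only, none or still open, it means among the compounds named here.

Measured so far in a physicochemical assay for lipophilicity, at pH 7.4; on this read-out lower numbers stand for lower lipophilicity and higher numbers for higher lipophilicity:
Compound 1 `Cc1cc(C(N)=O)nn1Cc1cc(Cl)ccc1OCc1ccccc1` gives 3.7.
Compound 2 `Cc1cc(C(=O)NCc2ccncc2)nn1Cc1cc(Cl)ccc1OCc1ccccc1` gives > 3.7, which is a limit of the assay.
Compound 3 `Cc1cc(NC(=O)C(C)C)nn1Cc1cc(Cl)ccc1OCc1ccccc1` gives > 3.7, likewise a limit of the assay.

Compound 3 therefore stands only at a limit in this assay, with no number of its own. Two of the three measured steps end at that same limit (the limit of > 3.7 in this assay, at which 2 of the 3 values shown sit), so their sizes are not readable: from compound 1 to compound 2 the step is a number no lower from compound 1 to compound 2 (the limit leaves the size open), and from compound 1 to compound 3 it is a number no lower from compound 1 to compound 3 (the limit leaves the size open). The step that the two limits leave unreadable from compound 2 to compound 3 between the two limit values cannot be read at all.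

Compound 4 `Cc1cc(NC(=O)c2ccccc2)nn1Cc1cc(Cl)ccc1OCc1ccccc1` differs from compound 3 in one place: phenyl in place of isopropyl on a carbonyl carbon. For the measured compounds named here, none of the measured steps carries a readable size that bears directly on this change; what they show is that the series already sits at or beyond the limit in this assay. Compound 4 is expected to remain at or beyond that limit, with a step that the limit leaves unreadable from compound 3 to compound 4 that the data cannot anchor. Compound 4 is estimated at 4.6, in the range 3.9 to 5.3, most likely reported again only as a limit.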

Compound 4, distribution coefficient: > 3.7
Compound 4 gave a limit, no number; the forecaster's own chance of this, stated with the estimate: 85%; the middle value lies beyond the limit too.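

Phenyl in place of isopropyl on a carbonyl carbon leaves the reading in this assay where it was, at a limit rather than a number, and the two new steps that run between two limits cannot be read. For benzamido in place of carbamoyl on an aromatic carbon, the step is a number no lower from compound 1 to compound 4 (the limit leaves the size open). The earlier compounds shown here showed this limit for isopropylcarbonyl; compound 4 shows that the benzoyl analogue gives no number either. The series now sits largely at one limit: the limit of > 3.7 in this assay, at which 3 of the 4 values shown sit.

From the compounds shown here alone, whether phenyl or isopropyl gives the higher value on this read-out stays open, as does the size of any change at this position. Also open, going by these compounds, is whether a chain carrying a carboxylic acid or an amine, in place of phenyl on that carbonyl carbon, would give a value inside the readable range of this assay.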